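The source may hold more compounds than are shown below. What is called first, only, known or untested is meant among the compounds shown, and "the series" means these compounds.

In a functional assay on K562 cells (Homo sapiens) for cytotoxicity, read by MTT assay, with a stated time of 72 h (a lower number here means a stronger inhibitor, a higher number a weaker inhibitor), compound 1 `CC(C)(C)C1=CC(=O)C=C(NCC(=O)O)C1=O` reads 85000 nM and compound 2 `CC1=CCC[C@H]2[C@](C)(CC3=CC(=O)C=C(NCCC(=O)O)C3=O)[C@@H](C)CC[C@]12C` reads 15500 nM as the lower of the two numbers, with the gap between them beyond the scatter. This pair differs in more than one place, so no single structural change can be read from it.

Compound 3 `CC1=CCC[C@H]2[C@](C)(CC3=CC(=O)C=C(N[C@@H](C)C(=O)O)C3=O)[C@@H](C)CC[C@]12C` has the same atoms as compound 2, joined differently. The change 1-carboxyethyl in place of 2-carboxyethyl on an amine nitrogen puts 1-carboxyethyl in place of 2-carboxyethyl on an amine nitrogen. For the measured compounds named here, no measured compound yet carries the 1-carboxyethyl group, and no measured step covers this change.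

The expectation therefore rests on compound 2 at 15500 nM alone, and no shift beyond the scatter is foreseen in this assay in either direction. The estimated move is a 1.1-fold lower number from compound 2 to compound 3 (0.04 log units; within the scatter) and it is expected to stay within the usual scatter of repeated readings. For compound 3 the expected value is 14000 nM with an estimated range from 6500 nM to 30000 nM as the working figure.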

Compound 3, half-maximal inhibitory concentration: 15800 nM
Compound 3: middle estimate off by 1.1-fold (0.05 log units), on the low side, within the range that was stated.
By their numbers in this assay, from the lowest: compounds 2 and 3 (each within the scatter of the next); then compound 1.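

In this assay, 1-carboxyethyl in place of 2-carboxyethyl on an amine nitrogen whose other neighbour is a double-bonded ring carbon gives a 1.0-fold higher number from compound 2 to compound 3 (0.01 log units; within the scatter). For the compounds shown here, this is the first single-place step, as compound 1 and compound 2 differ in more than one place and could say nothing about this nitrogen on their own. With the shared core held constant, rearranging the same atoms of this side chain and introducing a defined stereocentre leaves the two readings within the scatter of each other, and no accompanying measurement bears on this result.

On these data alone, whether a longer chain such as 3-carboxypropyl, a methyl ester in place of the carboxylic acid, or an aminoethyl group in place of 2-carboxyethyl on the amine nitrogen would keep the reading in this range remains open, as does the effect of the opposite stereocentre in 1-carboxyethyl. The contribution of the shared core of compound 2 and compound 3 also remains unassigned, since compound 1 differs from both in more than one place.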